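From 4-nitrobenzyl to 2-(trifluoromethyl)benzyl in the series

The compounds below may be only part of what the source reports. "The series", "measured", "known", "first", "only" and "open" are said of these compounds alone.

In a functional assay on A-375 cells (Homo sapiens) for antiproliferative activity, read by MTT assay, with a stated time of 24 h (on this read-out higher numbers stand for weaker inhibition and lower numbers for stronger inhibition), compound 3 `COc1cc(OC)c(-c2coc3cc(OCc4ccc([N+](=O)[O-])cc4)ccc3c2=O)cc1OC` gives > 10000 nM, which is a limit of the assay and not a number. Its standing rests only on (the limit of > 10000 nM in this assay, at which 1 of the 3 values shown sits). The two measured neighbours are compound 1 `C#CCOc1ccc2c(=O)c(-c3cc(OC)c(OC)cc3OC)coc2c1` at 3680 nM and compound 2 `COc1cc(OC)c(-c2coc3cc(OCc4ccc(Br)cc4)ccc3c2=O)cc1OC` at 1000 nM.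

Compound 4 `COc1cc(OC)c(-c2coc3cc(OCc4ccccc4C(F)(F)F)ccc3c2=O)cc1OC` carries 2-(trifluoromethyl)phenyl in place of the 4-nitrophenyl of compound 3, on a saturated chain carbon bound to an oxygen on an aromatic ring: 2-(trifluoromethyl)phenyl in place of 4-nitrophenyl on a saturated chain carbon bound to an oxygen on an aromatic ring.

The nearest measured change is an at least 10-fold higher number from compound 2 to compound 3 (1.00 log units; beyond the scatter), with nitro in place of bromo on an aromatic carbon. The other two steps are an at least 2.7-fold higher number from compound 1 to compound 3 (0.43 log units; beyond the scatter) and a 3.7-fold lower number from compound 1 to compound 2 (0.57 log units; beyond the scatter). For the measured compounds named here, no measured compound carries 2-(trifluoromethyl)phenyl, so these steps bear on it only indirectly. Leaving the 4-nitrophenyl group is expected to bring a lower number in this assay, given that compound 2 reaches 1000 nM.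

The expected change is an at least 3.3-fold lower number from compound 3 to compound 4 (0.52 log units; beyond the scatter), a step of moderate size. Compound 4 is estimated at 3000 nM, with an expected range of 800 nM to 10000 nM.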

Compound 4, half-maximal inhibitory concentration: > 10000 nM
Compound 4 ended at the assay's limit; the forecaster's own chance of this, stated with the estimate: 20%; middle value at least 3.3-fold (0.52 log units) away from the limit.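

In this assay compound 4 gives > 10000 nM, which is a limit of the assay and not a number. For the compounds shown here, putting 2-(trifluoromethyl)phenyl in place of 4-bromophenyl brings an at least 10-fold higher number from compound 2 to compound 4 (1.00 log units; beyond the scatter), and putting it in place of ethynyl brings an at least 2.7-fold higher number from compound 1 to compound 4 (0.43 log units; beyond the scatter), so on this saturated chain carbon 4-nitrophenyl is no longer the only group that falls behind both compound 1 and compound 2. The step from compound 3 to compound 4 cannot be read, and 4-nitrophenyl and 2-(trifluoromethyl)phenyl cannot be ranked, as both values are limits: the limit of > 10000 nM in this assay, at which 2 of the 4 values shown sit.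

Among the substituted phenyl groups shown, only 4-bromophenyl gives a number, and whether that depends on the bromo group or on where it sits stays open. Also open, as far as these compounds go, is whether an amine or a carboxylic acid on that phenyl ring would give a number at all.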